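Replacing the benzyl amide with a propyl amide

A few compounds are considered here, and "the series" means these few. Any claim that something is new, unique, unknown or untested is made for them only; others in the source may bear on it.

Of the compounds shown here, three of one shared core have been tested in a functional assay on QGY7701 cells (Homo sapiens) for cytotoxicity, read by MTT assay, with a stated time of 24 h; on this read-out higher numbers stand for weaker inhibition and lower numbers for stronger inhibition. Compound 1, `C=CC1=C(C(=O)NCc2ccccc2)C(c2ccc(OC)c(OC)c2)OC1`, reaches only the limit of this assay, giving > 100000 nM. Compound 2, `C=CC1=C(C(=O)NCc2ccccc2)C(c2ccc(OC)cc2)OC1`, likewise stops at that limit, giving > 100000 nM. Going by the values given here, compound 3, `C=CC1=C(C(=O)NCc2ccccc2)C(c2ccc(F)cc2)OC1`, is the only one with a number in this assay, giving 67600 nM. The step from compound 1 to compound 2, a hydrogen in place of methoxy on an aromatic carbon, is a step that the two limits leave unreadable from compound 1 to compound 2. The step from compound 2 to compound 3, a fluoro in place of methoxy on an aromatic carbon, is an at least 1.4-fold lower number from compound 2 to compound 3 (0.17 log units; that floor lies within the scatter). Compound 2 therefore stands at the limit shared by two of the three values, as stated in the limit of > 100000 nM in this assay, at which 2 of the 3 values shown sit.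

Compound 4, `C=CC1=C(C(=O)NCCC)C(c2ccc(OC)cc2)OC1`, differs from compound 2 on the amide side: ethyl in place of phenyl on a saturated chain carbon bound to an amide-type nitrogen. Neither measured step touches this part of the core; both alter the aromatic ring only, and neither gives a readable size. Among the compounds with values here, no measured step bears on this change, so the expected step from compound 2 to compound 4 is a number no higher from compound 2 to compound 4 (the limit leaves the size open), none beyond the scatter, in either direction. Compound 4 is thus estimated at 100000 nM, within 40000 nM to 300000 nM, most likely again at the limit.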

Compound 4, half-maximal inhibitory concentration: > 100000 nM
Compound 4: only a limit was reported; the forecaster's own chance of this, stated with the estimate: 70%; the middle value lies on the limit itself.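

In this assay compound 4 gives > 100000 nM, which is a limit. Compound 2 also stands at a limit, so no new step can be read between compound 2 and compound 4. The compounds shown leave open what benzyl to propyl does to the number in this assay.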